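A Ring Swap on the Amide Side of Compound 2

The source may report more compounds than this note shows. Statements on the series, on what has been measured and on what is new or still open speak of the compounds shown alone.

Measured so far:
compound 1 `Cc1ccc(C)c(COc2cc([N+](=O)[O-])ccc2NS(C)(=O)=O)c1`: 370 nM
compound 2 `O=C(Nc1ccc([N+](=O)[O-])cc1OCc1ccccc1)C1CCCCC1`: > 25000 nM

Of the compounds shown here, two have been tested in an assay on SK-BR-3 cells for inhibition of Aromatase (Homo sapiens); a lower number here means a stronger inhibitor, a higher number a weaker inhibitor. Compound 1 gives 370 nM. For compound 2 the result is only a limit, > 25000 nM, so no exact number is known for it. This is the case described by the limit of > 25000 nM in this assay, at which 1 of the 2 values shown sits.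

Compound 3 `O=C(Nc1ccc([N+](=O)[O-])cc1OCc1ccccc1)c1ccc(Cl)c([N+](=O)[O-])c1` differs from compound 2 in one place: 4-chloro-3-nitrophenyl in place of cyclohexyl on a carbonyl carbon. Among the compounds with values here, no measured pair shows this kind of change, so its effect cannot be read from the numbers at hand. The expectation is a move toward stronger inhibition in this assay, of the size an at least 2.0-fold lower number from compound 2 to compound 3 (0.31 log units; beyond the scatter), though with wide uncertainty. The half-maximal inhibitory concentration of compound 3 is estimated at 12000 nM, with a likely range from 2000 nM to 60000 nM, and a real chance that compound 3 again returns only a limit.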

Compound 3, half-maximal inhibitory concentration: > 25000 nM
Compound 3: a limit, no number (the forecaster's own chance of this, stated with the estimate: 50%); at least 2.0-fold (0.31 log units) between middle value and limit.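

Compound 2 and compound 3 each return only a limit in this assay, so no step between them can be read: the limit of > 25000 nM in this assay, at which 2 of the 3 values shown sit.

From the compounds shown here alone, whether 4-chloro-3-nitrophenyl in place of cyclohexyl on a carbonyl carbon changes inhibition at all, and in which direction, stays open.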